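Replacing the phenyl group with isopropyl in compound 3

The compounds below may be only part of what the source reports. "The series", "measured", "known", "first", "only" and "open" are said of these compounds alone.

Compound 2 `COc1ccc(Nc2cc(-c3ccccc3)oc(=O)c2)cc1` gives 0.098 uM in a functional assay on KBVIN cells (Homo sapiens) for cytotoxicity, read by MTT assay, with a stated time of 72 h; on this read-out lower numbers stand for an effect already at smaller amounts and higher numbers for an effect only at larger amounts of compound; compound 1 `COc1ccc(Nc2cc(/C=C/c3ccccc3)oc(=O)c2)cc1` gives 0.1 uM, and the two stand within the scatter of each other, as the step of a 1.0-fold lower number from compound 1 to compound 2 (0.01 log units; within the scatter) shows. Compound 3 `COc1ccc(Nc2cc(C(C)C)oc(=O)c2)cc1` differs from compound 2 by isopropyl in place of phenyl on an aromatic carbon. For the measured compounds named here, the only measured step exchanged one ring-bearing group for another and left this assay unchanged, so it gives no direct guide to an open-chain group entering. Compound 3 is therefore expected to show a modest rise, a 4.1-fold higher number from compound 2 to compound 3 (0.61 log units; beyond the scatter), with an estimated value of 0.4 uM, ranging from 0.1 uM to 1.6 uM.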

Compound 3, concentration for half-maximal effect: > 30 uM
Compound 3: a limit, no number; the forecaster's own chance of this, stated with the estimate: 5%; at least 75-fold (1.87 log units) between middle value and limit.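

Compound 3 gives no number, only a limit: the limit of > 30 uM in this assay, at which 1 of the 3 values shown sits.

At this position, next to the ring oxygen, the earlier exchange of 2-phenylethenyl for phenyl changed nothing beyond the scatter in this assay, whereas isopropyl, with no ring, gives an at least 300-fold higher number from compound 2 to compound 3 (2.48 log units; beyond the scatter) and an at least 300-fold higher number from compound 1 to compound 3 (2.47 log units; beyond the scatter). The position therefore accepts both ring-bearing groups shown but loses the effect with this small open-chain group.

The compounds shown leave open whether an aromatic ring is needed here or any larger group would serve. Cyclohexyl, a saturated ring, or a longer chain such as n-hexyl could separate these two readings.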